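This account rests on a few compounds, and the source may have more. Where it says the series, first, only, none or still open, it means among the compounds named here.

Working notes on the series. Compound 1 `Nc1ccccc1NC(=O)c1ccc(CSC(=S)N2CCN(C3CCCCC3)CC2)cc1` gives 76.1% in a functional assay on HeLa cells (Homo sapiens) for antiproliferative activity, read by CCK-8 assay, with a stated time of 72 h, tested at 8 uM; a higher number here means a stronger effect of the compound at the concentration tested, a lower number a weaker effect. Compound 2 `Nc1ccccc1NC(=O)c1ccc(CSC(=S)N2CCN(Cc3ccncc3)CC2)cc1` gives 72.9%, and a number 3.2 percentage points lower from compound 1 to compound 2 (within the scatter). Compound 3 `Nc1ccccc1NC(=O)c1ccc(CSC(=S)N2CCN(Cc3ccccc3)CC2)cc1` gives 31.3% and stands lowest of the three; both replacements of cyclohexyl were costly here, with a number 44.8 percentage points lower from compound 1 to compound 3 (beyond the scatter) and likewise a number 41.6 percentage points lower from compound 2 to compound 3 (beyond the scatter). Compound 4 `Nc1ccccc1NC(=O)c1ccc(CSC(=S)N2CCN(c3ncccn3)CC2)cc1` differs from compound 3 as follows: pyrimidin-2-yl in place of benzyl on an amine nitrogen in a ring. Among the compounds with values here, no measured pair swaps an aryl group bound directly to the ring nitrogen, so the bearing on this step is indirect. The nearest comparison is the step from compound 2 to compound 3, where replacing pyridin-4-yl by phenyl on the chain carbon lost much; reversing that logic, bringing two ring nitrogens into the aryl group in compound 4 is expected to recover a good part of the loss, with a number 23.7 percentage points higher from compound 3 to compound 4 (beyond the scatter) expected in this assay. Within the data shown here, the benzyl group is also shortened by one carbon, which no measured step covers, so the range is wide. Compound 4 is estimated at 55%, between 30% and 78%.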

Compound 4, a percentage reported as inhibition, at one concentration (the size of the read-out at that concentration, not a potency): 73.9%
Compound 4: the middle estimate sits 18.9 percentage points below what was measured, and the stated range covers the measured number.
By their numbers in this assay, from the lowest: compound 3; then compounds 2, 4 and 1 (each within the scatter of the next).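

The step of a number 42.6 percentage points higher from compound 3 to compound 4 (beyond the scatter) shows that in this assay the low number of compound 3 is not shared by a group on this amine nitrogen that carries an aromatic ring with 2 hetero atoms and no chain carbon, while a number 1 percentage points higher from compound 2 to compound 4 (within the scatter) and a number 2.2 percentage points lower from compound 1 to compound 4 (within the scatter) place pyrimidin-2-yl level with (pyridin-4-yl)methyl and cyclohexyl. Among the four groups, benzyl alone now stands apart; a ring nitrogen in the group is no requirement, as cyclohexyl in compound 1 goes against that reading. Nothing at hand bears on what lies behind this difference.

The step to compound 4 changes the ring atoms and the chain carbon together, so a phenyl or a (pyrimidin-2-yl)methyl group on this nitrogen would be needed to separate the two. Going by these compounds, with one concentration only, whether compound 1, compound 2 and compound 4 would show a stronger or weaker effect than one another at other concentrations also remains open.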